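From isopropyl to 3-fluorophenyl on an aromatic carbon

The source may report more compounds than this note shows. Statements on the series, on what has been measured and on what is new or still open speak of the compounds shown alone.

Measured in a functional assay on HCT-116 cells (Homo sapiens) for antiproliferative activity, read by MTT assay, with a stated time of 72 h; on this read-out lower numbers stand for stronger inhibition and higher numbers for weaker inhibition:
Compound 1 `O=C(CCc1cccc2c1B(O)OC2)Nc1ccccc1`: 350 nM
Compound 2 `O=C(CCc1cccc2c1B(O)OC2)NCc1ccccc1`: > 100000 nM (a limit)
Compound 3 `CC(C)c1cccc(NC(=O)CCc2cccc3c2B(O)OC3)c1`: 1600 nM

Compound 3 holds the higher of the two actual numbers, with compound 1 lower. Compound 4 `O=C(CCc1cccc2c1B(O)OC2)Nc1cccc(-c2cccc(F)c2)c1` carries 3-fluorophenyl in place of isopropyl on an aromatic carbon, meta to a large group: 3-fluorophenyl in place of isopropyl on an aromatic carbon. The closest measured change is a 4.6-fold higher number from compound 1 to compound 3 (0.66 log units; beyond the scatter), a modest step that also sits on an aromatic carbon. The large at least 280-fold higher number from compound 1 to compound 2 (2.45 log units; beyond the scatter) concerns an amide-type nitrogen instead and bears little on this change. In this assay, a slight rise in the number is therefore expected, and the expected change is a 1.6-fold higher number from compound 3 to compound 4 (0.19 log units; within the scatter), which stays within the scatter. For compound 4 the estimated value is 2500 nM, with an expected range from 500 nM to 12000 nM.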

Compound 4, half-maximal inhibitory concentration: 460 nM
Compound 4: the middle estimate sits 5.4-fold (0.74 log units) above what was measured, and the stated range ends above it.
By their numbers in this assay, from the lowest: compounds 1 and 4 (each within the scatter of the next); then compound 3. At a limit, above all of these: compound 2.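

In this assay, 3-fluorophenyl in place of isopropyl gives a 3.5-fold lower number from compound 3 to compound 4 (0.54 log units; beyond the scatter) on this aromatic carbon, so the drop seen with isopropyl does not extend to every larger group there. With hydrogen in place of 3-fluorophenyl as the reference, the change is a 1.3-fold higher number from compound 1 to compound 4 (0.12 log units; within the scatter) and stays within the scatter, so this carbon tolerates an added aromatic ring in this assay. Nothing measured here explains the difference between the two groups. From the compounds shown here alone, how an amine or a carboxylic acid on this aromatic carbon would compare stays open, as does what a phenyl group without fluorine would give.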